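Replacing Propyl With a Bromophenyl Ring on the Carbonyl

This account rests on a few compounds, and the source may have more. Where it says the series, first, only, none or still open, it means among the compounds named here.

Three compounds have been measured in an assay on LtK cells with ATP-sensitive inward rectifier potassium channel 11 (Homo sapiens) as the target; a lower number here means that less compound is needed, a higher number that more compound is needed for the effect:

compound 1, `CCCC(=O)Nc1c(C(O)(C(F)(F)F)C(F)(F)F)ccc2ccccc12`, with 131 nM
compound 2, `O=C(NCCCCCCCl)Nc1c(C(O)(C(F)(F)F)C(F)(F)F)ccc2ccccc12`, with 4840 nM
compound 3, `O=C(Nc1c(C(O)(C(F)(F)F)C(F)(F)F)ccc2ccccc12)c1ccccc1Cl`, with 2040 nM

Compound 1 has the lowest number of the three in this assay. Its nearest neighbour is compound 3, and the gap between them is a 16-fold higher number from compound 1 to compound 3 (1.19 log units; beyond the scatter), while the gap to compound 2 is a 37-fold higher number from compound 1 to compound 2 (1.57 log units; beyond the scatter). Between the two larger compounds, the change from the (6-chlorohexyl)amino group to the 2-chlorophenyl group gives a 2.4-fold lower number from compound 2 to compound 3 (0.38 log units; beyond the scatter).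

Compound 4, `O=C(Nc1c(C(O)(C(F)(F)F)C(F)(F)F)ccc2ccccc12)c1cccc(Br)c1`, keeps the shared core and differs from compound 1 in one place: 3-bromophenyl in place of propyl on a carbonyl carbon.

Among the measured compounds shown here, the step that bears most directly on this change is the one from compound 1 to compound 3, where an aromatic ring also took the place of the propyl group on the carbonyl carbon and the number rose by a 16-fold higher number from compound 1 to compound 3 (1.19 log units; beyond the scatter). On that basis the number for compound 4 is expected to rise as well, by a step of about an 11-fold higher number from compound 1 to compound 4 (1.06 log units; beyond the scatter). Compound 4 is therefore estimated at 1500 nM in this assay, with a likely range from 400 nM to 6000 nM.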

Compound 4, half-maximal effective concentration: 80 nM
Compound 4: the middle estimate sits 19-fold (1.27 log units) above what was measured; measured number outside the range, below it.
By their numbers in this assay, from the lowest: compounds 4 and 1 (each within the scatter of the next); then compound 3; then compound 2.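

In this assay, putting 3-bromophenyl in place of propyl on the carbonyl carbon gives a 1.6-fold lower number from compound 1 to compound 4 (0.21 log units; within the scatter), so an aromatic ring at this position is compatible with a number that cannot be told apart from that of the propyl compound, and the ring as such does not bring the rise seen with compound 3. The identity of the ring matters instead: 3-bromophenyl in place of 2-chlorophenyl gives a 26-fold lower number from compound 3 to compound 4 (1.41 log units; beyond the scatter), a large step between two groups that each carry a six-membered aromatic ring of carbon only and one halogen. The step with 3-bromophenyl in place of (6-chlorohexyl)amino, a 61-fold lower number from compound 2 to compound 4 (1.78 log units; beyond the scatter), is larger still and places compound 4 with compound 1, well clear of the other two compounds.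

Between compound 3 and compound 4, the halogen and its place on the ring change together, and the compounds shown do not separate the two; a plain phenyl ring, a 3-chlorophenyl ring or a 2-bromophenyl ring would begin to do so. No measurement at hand explains the large difference between these two rings.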